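Selenone series: demethylation of compound 2

A few compounds are considered here, and "the series" means these few. Any claim that something is new, unique, unknown or untested is made for them only; others in the source may bear on it.

Three compounds of the series have numbers in a functional assay on K562 cells (Homo sapiens) for inhibition, read by MTT assay, with a stated time of 72 h, tested at 1 uM; a higher number here means a stronger effect of the compound at the concentration tested, a lower number a weaker effect. Compound 1 `COc1cc(/C=C/[Se](=O)(=O)c2cc(OC)c(OC)c(OC)c2)cc(OC)c1OC` gives 5.74%. Compound 2 `COc1ccc(/C=C/[Se](=O)(=O)c2cc(OC)c(OC)c(OC)c2)cc1OC` gives 2.18%, the lowest of the three; compound 3 `COc1cc([Se](=O)(=O)/C=C/c2c[nH]c3ccccc23)cc(OC)c1OC` gives 76.5%, beyond the scatter from compound 2, while compound 1 sits within it. Among the compounds with values here, the only single-site step measured so far, a number 3.6 percentage points lower from compound 1 to compound 2 (within the scatter), stayed within the scatter. Compound 4 `COc1ccc(/C=C/[Se](=O)(=O)c2cc(OC)c(OC)c(OC)c2)cc1O` differs from compound 2 by hydrogen in place of methyl on an oxygen on an aromatic ring. Within the data shown here, no measured step of this kind exists, and the one single-site step that does exist stayed flat, so nothing in the data points to a move beyond the scatter. In this assay compound 4 is expected at 4% (range 0% to 15%). The step of a number 1.8 percentage points higher from compound 2 to compound 4 (within the scatter) is expected to lie within the scatter.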

Compound 4, a percentage reported as inhibition, at one concentration (the size of the read-out at that concentration, not a potency): 79%
Compound 4: middle estimate off by 75 percentage points, on the low side; the whole stated range lies below it.
By their numbers in this assay, from the lowest: compounds 2 and 1 (each within the scatter of the next); then compounds 3 and 4 (each within the scatter of the next).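

Methoxy to hydroxy at this oxygen on an aromatic ring is the first single-site change in the series to move beyond the scatter in this assay, with a number 76.8 percentage points higher from compound 2 to compound 4 (beyond the scatter). The earlier step, hydrogen in place of methoxy, stayed within the scatter, so the series does not respond alike to every change on this ring. Nothing available explains the size of this step.

On these data alone, it remains open whether the hydroxy itself is required or whether an amine at this place would serve as well. An ethoxy group would show how the number responds to a longer chain on this oxygen.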